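The source may report more compounds than this note shows. Statements on the series, on what has been measured and on what is new or still open speak of the compounds shown alone.

In an ADME assay on MDCK cells (Canis lupus familiaris) for cytotoxicity, read by MTT assay, with a stated time of 24 h (on this read-out higher numbers stand for lower toxicity in this test and lower numbers for higher toxicity in this test), compound 1 (`O=[N+]([O-])c1ccc(S(=O)(=O)NCc2ccoc2)cc1`) gives > 236000 nM as a limit of the assay and not a number, so its standing is known only as that limit. Compound 2 (`Cc1cc(CNS(=O)(=O)c2ccc(F)cc2)c(C)s1`) has the entry "not determined" (no result reported) and offers no comparison. Compound 3 (`O=[N+]([O-])c1ccc(S(=O)(=O)NCc2cccs2)cc1`) keeps the core of compound 1 and has thiophen-2-yl in place of furan-3-yl on a saturated chain carbon bound to a sulfonamide nitrogen. Going by the values given here, no measured step exists, so the step of an at least 1.0-fold lower number from compound 1 to compound 3 (0.01 log units; that floor lies within the scatter) is expected to stay within the usual scatter in this assay with no direction favoured. For compound 3 the estimated value is 230000 nM with an expected range from 100000 nM to 400000 nM and a report as a limit is considered likely.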

Compound 3, half-maximal cytotoxic concentration: 133000 nM
Beside the measured number, compound 3's estimate is 1.7-fold (0.24 log units) above it, within the range that was stated.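

Thiophen-2-yl in place of furan-3-yl on a saturated chain carbon bound to a sulfonamide nitrogen gives an at least 1.7-fold lower number from compound 1 to compound 3 (0.24 log units; that floor lies within the scatter) as the first step at this position and the first single number in the series. Going by these compounds, that step is only a floor, so the full size of the difference stays unknown. The entry for compound 1 is a limit of the assay and not a number: the limit of > 236000 nM in this assay, at which 1 of the 3 values shown sits.

On these data alone, whether the difference truly exceeds the scatter stays open. Also open, as far as these compounds go, is how an amine, a carboxylic acid or a longer chain at this place would read in this assay.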